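Swapping the piperazine substituent: from urea to benzyl

This account rests on a few compounds, and the source may have more. Where it says the series, first, only, none or still open, it means among the compounds named here.

Measured so far:
Compound 1, `COc1ccc(-c2cnc3nc(N)nc(N4CCN(C(=O)c5ccccc5)CC4)c3n2)cc1OC`: 400 nM
Compound 2, `COc1ccc(-c2cnc3nc(N)nc(N4CCN(c5ccc(F)cc5)CC4)c3n2)cc1OC`: 100 nM
Compound 3, `COc1ccc(-c2cnc3nc(N)nc(N4CCN(C(=O)Nc5ccc(C#N)cc5)CC4)c3n2)cc1OC`: 74 nM

All three compounds share one core and differ only in the group on an amine nitrogen in a ring. In a functional assay on cells (T-cell, Homo sapiens) for inhibition (a lower number here means a stronger inhibitor, a higher number a weaker inhibitor), compound 3 gives the lowest number of the three; compound 2 sits within the scatter of it, while compound 1 is clearly apart, as the step of a 5.4-fold lower number from compound 1 to compound 3 (0.73 log units; beyond the scatter) shows.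

Compound 4, `COc1ccc(-c2cnc3nc(N)nc(N4CCN(Cc5ccccc5)CC4)c3n2)cc1OC`, has not yet been tested in this assay. Its change from compound 3 is benzyl in place of (4-cyanophenyl)carbamoyl on an amine nitrogen in a ring. Among the measured compounds shown here, no measured step involves a benzyl group, so no step bears on it directly. The nearest guides are a 5.4-fold lower number from compound 1 to compound 3 (0.73 log units; beyond the scatter), where a change on the carbonyl carbon gave a modest gain, and a 1.4-fold lower number from compound 2 to compound 3 (0.13 log units; within the scatter), which stayed within the scatter. Going by these compounds, removing the carbonyl altogether, as here, is untested, so the expectation is uncertain: compound 4 is estimated to land somewhat weaker than compound 3, a step of a 3.4-fold higher number from compound 3 to compound 4 (0.53 log units; beyond the scatter).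

For compound 4 in this assay the expected value is 250 nM, with a range from 60 nM to 1000 nM.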

Compound 4, half-maximal inhibitory concentration: 900 nM
Compound 4: the middle estimate sits 3.6-fold (0.56 log units) below what was measured; the measured number falls inside the stated range.
By their numbers in this assay, from the lowest: compounds 3 and 2 (each within the scatter of the next); then compound 1; then compound 4.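

In this assay, benzyl on the amine nitrogen in the ring gives the weakest inhibitor of the four, with a 12-fold higher number from compound 3 to compound 4 (1.09 log units; beyond the scatter) and a 9.0-fold higher number from compound 2 to compound 4 (0.95 log units; beyond the scatter). Even against benzoyl, which also carries an unsubstituted benzene ring but has a carbonyl where benzyl does not, the result is a 2.3-fold higher number from compound 1 to compound 4 (0.35 log units; beyond the scatter), so this position responds to the link between the ring nitrogen and the aromatic ring, not merely to the presence of an aromatic ring. Both carbonyl-bearing groups give lower numbers than benzyl, but compound 2 goes against any simple rule that a carbonyl is needed, since its 4-fluorophenyl group has none and still gives a lower number than compound 4; no measurement available here explains the difference.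

The compounds shown leave open whether a fluorine or a nitrile on the benzyl ring would recover any of this loss, and whether a longer chain such as phenethyl would behave like benzyl. They also do not separate the urea from the nitrile in compound 3, which a plain phenyl urea at this position would do.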